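Replacing acetyl with chloro on the shared core

This account rests on a few compounds, and the source may have more. Where it says the series, first, only, none or still open, it means among the compounds named here.

Compound 3, `CC(=O)c1ccc(-c2cn3ccnc3c(-c3ccc4ncn(C5CCCCC5)c4c3)n2)cc1`, has the lowest of the three measured numbers. In a functional assay on UO-31 cells (Homo sapiens) for inhibition, read by sulforhodamine B assay, with a stated time of 48 h, tested at 10 uM (on this read-out lower numbers stand for less inhibition and higher numbers for more inhibition at the one concentration tested (going by the name of the read-out)), compound 3 gives 23.1%, while compound 1, `COc1ccc(-c2cn3ccnc3c(-c3ccc4ncn(C5CCCCC5)c4c3)n2)cc1`, gives 61.5% and compound 2, `O=Cc1ccc(-c2cn3ccnc3c(-c3ccc4ncn(C5CCCCC5)c4c3)n2)cc1`, gives 82.2%. Both steps that lead into compound 3 were large: a number 38.4 percentage points lower from compound 1 to compound 3 (beyond the scatter) and a number 59.1 percentage points lower from compound 2 to compound 3 (beyond the scatter). Compound 4, `Clc1ccc(-c2cn3ccnc3c(-c3ccc4ncn(C5CCCCC5)c4c3)n2)cc1`, is not yet measured; it differs from compound 3 as follows: chloro in place of acetyl on an aromatic carbon. Within the data shown here, no measured step carries the chloro group, so its own weight is unknown. What the measured steps show is that the acetyl group marks the low end of the set, and that the two other substituents on that ring stand well above it. Removing acetyl is therefore expected to raise the number, with a step of about a number 31.9 percentage points higher from compound 3 to compound 4 (beyond the scatter). Compound 4 is estimated at 55%, with a range from 25% to 85%.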

Compound 4, a percentage reported as inhibition, at one concentration (the size of the read-out at that concentration, not a potency): 36.1%
Estimate against measurement, compound 4: 18.9 percentage points above; the range from low to high includes it.
By their numbers in this assay, from the lowest: compound 3; then compound 4; then compound 1; then compound 2.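

Chloro in place of acetyl lifts the number only slightly in this assay (a number 13 percentage points higher from compound 3 to compound 4 (beyond the scatter)), while chloro stands well short of the two other groups at this position (a number 46.1 percentage points lower from compound 2 to compound 4 (beyond the scatter); a number 25.4 percentage points lower from compound 1 to compound 4 (beyond the scatter)). The low number of the acetyl compound therefore does not mean that any replacement of acetyl returns the level of the methoxy and formyl compounds, and the two carbonyl groups, formyl and acetyl, mark the opposite ends of the four. Nothing given here explains this order.

The compounds shown leave open how an amine, a hydroxyl or a carboxylic acid at this position would read out. They also leave open whether the order of the four would hold at other concentrations, since each compound is read at a single one.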